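This account rests on a few compounds, and the source may have more. Where it says the series, first, only, none or still open, it means among the compounds named here.

Working notes on the series.

The parent of the set is compound 1 `CC(=O)c1nn(-c2ccccc2)/c(=N/c2nc(-c3c(C)n(C)n(-c4ccccc4)c3=O)cs2)s1`, which in a functional assay on HepG2 cells (Homo sapiens) for cytotoxicity, read by sulforhodamine B assay, with a stated time of 72 h (on this read-out higher numbers stand for weaker inhibition and lower numbers for stronger inhibition), gives 67100 nM. Compound 2 `CC(=O)c1nn(-c2ccc(Cl)cc2)/c(=N/c2nc(-c3c(C)n(C)n(-c4ccccc4)c3=O)cs2)s1` carries chloro in place of hydrogen on an aromatic carbon of the phenyl attached to the five-membered ring of the shared core. In this assay compound 2 gives > 100000 nM, which is a limit of the assay and not a number; this is the limit of > 100000 nM in this assay, at which 1 of the 2 values shown sits. Going by the values given here, the only measured step is an at least 1.4-fold higher number from compound 1 to compound 2 (0.17 log units; that floor lies within the scatter), and its floor does not reach beyond the scatter, so the two values show no difference that can be read with confidence.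

Compound 3 `CC(=O)c1nn(-c2ccc(C)cc2)/c(=N/c2nc(-c3c(C)n(C)n(-c4ccccc4)c3=O)cs2)s1` is the next member: methyl in place of chloro on an aromatic carbon. Among the compounds with values here, the single measured step bears only loosely on this change, since it swaps hydrogen for chloro rather than chloro for methyl, and it did not move the read-out beyond the scatter. On that basis the step of a number no higher from compound 2 to compound 3 (the limit leaves the size open) is expected to stay within the scatter, with a real chance that compound 3 again returns only a limit. The estimate for compound 3 in this assay is therefore 100000 nM, expected to fall between 40000 nM and 300000 nM.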

Compound 3, half-maximal inhibitory concentration: 31700 nM
For compound 3 the middle estimate is 3.2-fold (0.50 log units) above the measured one, outside the stated range (below it).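

In this assay, the change from 4-chlorophenyl to 4-methylphenyl gives the first difference in the series that reads beyond the scatter, an at least 3.1-fold lower number from compound 2 to compound 3 (0.49 log units; beyond the scatter), and methyl also separates from hydrogen at the same place, with a 2.1-fold lower number from compound 1 to compound 3 (0.33 log units; beyond the scatter). The position on the six-membered aromatic ring, para to a large group, therefore does register in this read-out, and among the three compounds the lowest number belongs to compound 3, the methyl member. Compound 2 stands at a limit of the assay and not at a number, which leaves the size of its step open: the limit of > 100000 nM in this assay, at which 1 of the 3 values shown sits.

With only hydrogen, chloro and methyl at this position, the compounds shown cannot tell whether the lower number is particular to methyl or would also appear with an ethyl, a methoxy, an amine or a carboxylic acid in the same place. They also leave open whether methyl would give a similar step on the other phenyl of the shared core.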